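The compounds below may be only part of what the source reports. "The series", "measured", "known", "first", "only" and "open" are said of these compounds alone.

Measured compounds in a functional assay on SN12C cells (Homo sapiens) for inhibition, read by sulforhodamine B assay, with a stated time of 48 h; a lower number here means a stronger inhibitor of growth, a higher number a weaker inhibitor of growth:
- compound 1, `COc1cc(-c2cc(/C=C/C(=O)c3ccc(Cl)c(Cl)c3)[nH]n2)cc(OC)c1OC`: 13700 nM
- compound 2, `COc1ccc(-c2cc(/C=C/C(=O)c3cc(OC)c(OC)c(OC)c3)[nH]n2)cc1OC`: 1770 nM

Within the data shown here, of the two numbers known, compound 1 stands at the highest; the nearest is compound 2, which gives a lower number in this assay, a gap beyond the usual scatter. Among the measured compounds shown here, no step between these two has been worked out, so their two values are all that can be said of them.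

Compound 3, `COc1cc(-c2cc(/C=C/C(=O)c3ccc(F)c(F)c3)[nH]n2)cc(OC)c1OC`, has not yet been run in this assay. It differs from compound 1 in one place: 3,4-difluorophenyl in place of 3,4-dichlorophenyl on a carbonyl carbon. The remainder of the shared core is unchanged.

For the measured compounds named here, with no step of this kind known, the expectation rests on compound 1 alone, and the step of a 1.1-fold higher number from compound 1 to compound 3 (0.04 log units; within the scatter) is expected to stay within the scatter, with no clear direction. For compound 3 a value of about 15000 nM is estimated, within a range of 5000 nM to 45000 nM.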

Compound 3, concentration for 50% growth inhibition: 3370 nM
Beside the measured number, compound 3's estimate is 4.5-fold (0.65 log units) above it; measured number below the stated range.
By their numbers in this assay, from the lowest: compounds 2 and 3 (each within the scatter of the next); then compound 1.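

In this assay the group on the carbonyl carbon is not interchangeable among dihalophenyls: 3,4-difluorophenyl in place of 3,4-dichlorophenyl gives a 4.1-fold lower number from compound 1 to compound 3 (0.61 log units; beyond the scatter) with the rest of the shared core unchanged. Both groups have the same heavy-atom count, the same single aromatic ring, no hydrogen-bond donors or acceptors and no net charge, so the two compounds differ only in fluorine versus chlorine on that ring. Nothing available explains this difference.

From the compounds shown here alone, whether the number keeps falling with other groups here, such as unsubstituted phenyl, 3,4-dibromophenyl or a ring carrying a nitrile or an amine, remains open. Going by these compounds, it is also open whether the same exchange gives a step of similar size on a core with a different methoxy pattern.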